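This account rests on a few compounds, and the source may have more. Where it says the series, first, only, none or still open, it means among the compounds named here.

Measured in a functional assay on PC-12 cells (Rattus norvegicus) for cytotoxicity, read by MTT assay, with stated times of 2 h and 24 h, tested at 10 uM; on this read-out higher numbers stand for a stronger effect at the one concentration tested and lower numbers for a weaker effect:

compound 1, `Oc1cc(C(F)(F)F)ccc1-c1nc(-c2ccccc2O)n(-c2ccc(F)cc2)n1`, gives 99.8%
compound 2, `Oc1cc(C(F)(F)F)ccc1-c1nc(-c2ccccc2O)n(-c2ccc(C(F)(F)F)cc2)n1`, gives 102%
compound 3, `Oc1cc(C(F)(F)F)ccc1-c1nc(-c2ccccc2O)n(-c2ccc(F)cc2F)n1`, gives 97.9%

All three compounds share one core and differ only in the ring carried on the aromatic nitrogen. On the numbers shown, compound 3 sits within the scatter of both compound 1 and compound 2, so the three cannot be told apart. The step to compound 4, `Oc1cc(C(F)(F)F)ccc1-c1nc(-c2ccccc2O)n(-c2cc(F)cc(F)c2)n1`, is the change (3,5-difluorophenyl in place of 2,4-difluorophenyl on an aromatic nitrogen). Every measured step touches this same ring. Swapping the whole ring, a number 4.1 percentage points lower from compound 2 to compound 3 (within the scatter), changed nothing beyond the scatter, and neither did the smaller changes a number 2.2 percentage points higher from compound 1 to compound 2 (within the scatter) and a number 1.9 percentage points lower from compound 1 to compound 3 (within the scatter). Since moving the two fluorine atoms to new places on the ring is a change of the same kind, no step beyond the scatter is expected in this assay . Compound 4 is therefore expected to give about 99%, within a range of 89% to 108%, which means an expected step of a number 1.1 percentage points higher from compound 3 to compound 4 (within the scatter).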

Compound 4, a percentage reported as activity, at one concentration (the size of the read-out at that concentration, not a potency): 106%
Compound 4: middle estimate off by 7 percentage points, on the low side; the measured number falls inside the stated range.
By their numbers in this assay, from the lowest: compounds 3, 1, 2 and 4 (each within the scatter of the next).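

In this assay, among these compounds, this is the first change that keeps the same atoms on the ring at the aromatic nitrogen and only moves the two fluorine atoms, and it gives a number 8.1 percentage points higher from compound 3 to compound 4 (within the scatter). The comparisons with the other two rings give a number 4 percentage points higher from compound 2 to compound 4 (within the scatter) and a number 6.2 percentage points higher from compound 1 to compound 4 (within the scatter), so 3,5-difluorophenyl cannot be told apart from 2,4-difluorophenyl, 4-(trifluoromethyl)phenyl or 4-fluorophenyl at this position. No measurement available here speaks to why these values fall as they do.

All four rings carry fluorine, so the shown compounds cover only a narrow set of changes at this position. Whether a ring bearing an amine or a carboxylic acid would stay within the scatter of these compounds in this assay remains open.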